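This account rests on a few compounds, and the source may have more. Where it says the series, first, only, none or still open, it means among the compounds named here.

Compound 1 `Cc1ccc(C2C(C#N)=C(N)N(c3ccc(S(N)(=O)=O)cc3)C3=C2C(=O)CCC3)cc1` gives 100% in a functional assay on Ehrlich cells (Mus musculus) for antiproliferative activity, read by trypan blue exclusion, with a stated time of 2 h, tested at 100 ug/mL; a lower number here means a weaker effect, a higher number a stronger effect of the compound at the concentration tested.
Compound 2 `COc1ccc(C2C(C#N)=C(N)N(c3ccc(S(N)(=O)=O)cc3)C3=C2C(=O)CCC3)cc1` gives 100% in this assay.
Compound 3 `N#CC1=C(N)N(c2ccc(S(N)(=O)=O)cc2)C2=C(C(=O)CCC2)C1c1ccc([N+](=O)[O-])cc1` gives 100% in this assay.

Compound 1 stands level with compounds 2 and 3 at the digits shown; its nearest and furthest neighbours are reached by no change at the digits printed from compound 1 to compound 2 (within the scatter) and by no change at the digits printed from compound 1 to compound 3 (within the scatter). A third step, no change at the digits printed from compound 2 to compound 3 (within the scatter), completes the picture: every measured exchange of the substituent on the aromatic carbon left the read-out in this assay where it was. Compound 4 `N#CC1=C(N)N(c2ccc(S(N)(=O)=O)cc2)C2=C(C(=O)CCC2)C1c1ccc(Cl)cc1Cl` has not been measured; it differs from compound 1 by 2,4-dichlorophenyl in place of 4-methylphenyl on a saturated ring carbon. The three measured steps all lie within the scatter, and the data therefore give no sign that the group on this saturated ring carbon moves the read-out. Compound 4 is accordingly expected to show no step beyond the scatter, no change at the digits printed from compound 1 to compound 4 (within the scatter). The estimate for compound 4 is 100%, with a range from 85% to 100%. The range extends only downward because the read-out of compound 1 100% leaves no room above it.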

Compound 4, a percentage reported as activity, at one concentration (the size of the read-out at that concentration, not a potency): 95%
Beside the measured number, compound 4's estimate is 5 percentage points above it, and the stated range covers the measured number.
By their numbers in this assay, from the lowest: compounds 4, 1, 2 and 3 (each within the scatter of the next).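

Among these compounds, the earlier compounds changed only the group on the aromatic carbon of a 4-substituted phenyl, whereas this exchange places 2,4-dichlorophenyl on the saturated ring carbon, with chlorine entering the group for the first time. In this assay the exchange gives a number 5 percentage points lower from compound 1 to compound 4 (within the scatter) and a number 5 percentage points lower from compound 2 to compound 4 (within the scatter) and a number 5 percentage points lower from compound 3 to compound 4 (within the scatter) as its steps, so the read-out stays within the scatter whichever of the three earlier groups is replaced.

As far as these compounds go, all four groups are phenyl rings read at one concentration, so it remains open whether a pyridine ring, a butyl chain or a carboxylic acid on the phenyl ring at this saturated ring carbon would hold the read-out, and whether these four compounds differ in potency. Nothing measured here explains why the read-out holds across these groups.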